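A few compounds are considered here, and "the series" means these few. Any claim that something is new, unique, unknown or untested is made for them only; others in the source may bear on it.

In a functional assay on HL-60 cells (Homo sapiens) for inhibition, read by CCK-8 assay, with a stated time of 48 h, tested at 20 uM (a higher number here means more inhibition of growth at the concentration tested, a lower number less inhibition of growth), compound 2 `COc1ccc(Cc2nnc(NC(=O)/C(C#N)=C/c3ccccc3OS(=O)(=O)c3ccc(OC)cc3)s2)cc1` gives 100%, the highest of three closely related compounds. Compound 1 `COc1ccc(Cc2nnc(NC(=O)/C(C#N)=C/c3ccccc3OS(=O)(=O)c3ccc(C)cc3)s2)cc1` gives 25%, and compound 3 `COc1ccc(Cc2nnc(NC(=O)/C(C#N)=C/c3ccccc3OS(=O)(=O)c3ccc(Cl)cc3)s2)cc1` gives 20%. Swapping one group on an aromatic carbon shifted the result strongly in two cases: a number 75 percentage points higher from compound 1 to compound 2 (beyond the scatter) with methoxy in place of methyl, and a number 80 percentage points lower from compound 2 to compound 3 (beyond the scatter) with chloro in place of methoxy. The third swap, a number 5 percentage points lower from compound 1 to compound 3 (within the scatter), stays within the scatter.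

Compound 4 `COc1ccc(S(=O)(=O)Oc2ccccc2/C=C(\C#N)C(=O)Nc2nnc(Cc3cccc(F)c3)s2)cc1` keeps the methoxy group that those swaps varied and changes a different place: 3-fluorophenyl in place of 4-methoxyphenyl on a saturated chain carbon bound to an aromatic carbon. This puts 3-fluorophenyl in place of 4-methoxyphenyl on a saturated chain carbon bound to an aromatic carbon. Going by the values given here, no measured step touches this place, so the data give no direct size for the change, only a sign that single swaps can matter greatly. Because compound 2 already stands at 100%, a fall is the likelier direction. The expected result is a number 35 percentage points lower from compound 2 to compound 4 (beyond the scatter), a sizeable step beyond the scatter but with wide uncertainty. For compound 4 the estimated value is 65%, with an expected range of 25% to 100%.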

Compound 4, percent growth inhibition at one concentration: 100%
Compound 4: middle estimate off by 35 percentage points, on the low side; the range from low to high includes it.
By their numbers in this assay, from the lowest: compounds 3 and 1 (each within the scatter of the next); then compounds 2 and 4 (each within the scatter of the next).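

In this assay, the read-out shows no change at the digits printed from compound 2 to compound 4 (within the scatter), so 3-fluorophenyl can take the place of 4-methoxyphenyl on a saturated chain carbon bound to an aromatic carbon without any loss of growth inhibition. Unlike the swaps at the other place, one of which gave a number 80 percentage points lower from compound 2 to compound 3 (beyond the scatter), this change leaves the result intact, even though the entering group has no hydrogen-bond acceptor and the leaving group has one. No measurement here explains why the two groups give matching results.

Both compounds sit at the top of this single-concentration read-out, so any difference that would appear at lower concentrations stays hidden. As far as these compounds go, it also remains open whether this place would accept a carboxylic acid or an amine on the ring, or a longer chain in place of the benzyl group.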